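Moving the dimethylamino group around the benzyl ring

The source may hold more compounds than are shown below. What is called first, only, known or untested is meant among the compounds shown, and "the series" means these compounds.

Three members of the series have been measured in an assay on isolated protein for inhibition of Amine oxidase [flavin-containing] B (Homo sapiens); on this read-out higher numbers stand for weaker inhibition and lower numbers for stronger inhibition. Compound 1 `CCN(CCCCCCOc1ccc(C(=O)/C=C/c2ccc(N(C)C)cc2)c(O)c1)Cc1ccccc1` gives 2100 nM. Compound 2 `CCN(CCCCCCOc1ccc(C(=O)/C=C/c2ccc(N(C)C)cc2)c(O)c1)Cc1ccccc1OC` gives 700 nM, and the methoxy substitution reads a 3.0-fold lower number from compound 1 to compound 2 (0.48 log units; beyond the scatter). Compound 3 `CCN(CCCCCCOc1ccc(C(=O)/C=C/c2ccc(N(C)C)cc2)c(O)c1)Cc1ccccc1N(C)C` gives 2100 nM; relative to the unsubstituted benzyl arm the change is no change at the digits printed from compound 1 to compound 3 (within the scatter), and against the methoxy analogue it is a 3.0-fold higher number from compound 2 to compound 3 (0.48 log units; beyond the scatter). Among the compounds with values here, compound 3 therefore sits level with compound 1 at the digits given, the two together being the highest numbers of the three, with compound 2 the only member set apart from them.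

Compound 4 `CCN(CCCCCCOc1ccc(C(=O)/C=C/c2ccc(N(C)C)cc2)c(O)c1)Cc1ccc(N(C)C)cc1` carries the same atoms arranged differently: 4-(dimethylamino)phenyl in place of 2-(dimethylamino)phenyl on a saturated chain carbon bound to an amine nitrogen. Within the data shown here, none of the measured steps moves a substituent from one ring carbon to another; the steps so far only exchange the group on a single position. The steps from compound 1 and compound 2 to compound 3 set the scale of what substituent identity on this ring has done, and nothing larger than that is suggested for a positional shift. The expected step is a 1.1-fold lower number from compound 3 to compound 4 (0.02 log units; within the scatter), that is, no change beyond the scatter. Compound 4 is estimated at 2000 nM, with a range from 700 nM to 6000 nM.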

Compound 4, half-maximal inhibitory concentration: 2300 nM
Estimate against measurement, compound 4: 1.2-fold (0.06 log units) below; low and high end bracket the measured number.
By their numbers in this assay, from the lowest: compound 2; then compounds 1, 3 and 4 (each within the scatter of the next).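

In this assay, within the data shown here, this is the first step that changes where a group stands on the benzyl ring and not which group stands there: 4-(dimethylamino)phenyl in place of 2-(dimethylamino)phenyl on a saturated chain carbon bound to an amine nitrogen gives no shift beyond the scatter (a 1.1-fold higher number from compound 3 to compound 4 (0.04 log units; within the scatter)). Among these compounds, the 4-(dimethylamino)phenyl arm also stays within the scatter of the unsubstituted benzyl arm (a 1.1-fold higher number from compound 1 to compound 4 (0.04 log units; within the scatter)), so neither placement of dimethylamino separates from hydrogen, while compound 2 remains the only member of the four set apart (a 3.3-fold higher number from compound 2 to compound 4 (0.52 log units; beyond the scatter)). No evidence at hand bears on what lies behind these readings.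

A 4-methoxyphenyl arm would show whether the lower number of compound 2 depends on where the methoxy group stands, and a 2-ethoxyphenyl or 2-chlorophenyl arm whether it is tied to methoxy itself. Also open, on these data alone, are a 3-(dimethylamino)phenyl arm and whether the same flat reading holds with a methyl in place of the ethyl on the amine nitrogen.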